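From trifluoromethyl to hydroxy on an aromatic carbon

A few compounds are considered here, and "the series" means these few. Any claim that something is new, unique, unknown or untested is made for them only; others in the source may bear on it.

Measured in a functional assay on NCI-H460 cells (Homo sapiens) for inhibition, read by MTT assay, with a stated time of 72 h; on this read-out lower numbers stand for stronger inhibition and higher numbers for weaker inhibition
- compound 1 `COc1cc(NC(C)CCCNC(=O)NNC(=O)Nc2ccc(F)cc2)c2ncccc2c1` gives > 100000 nM
- compound 2 `COc1cc(NC(C)CCCNC(=O)Nc2ccc(F)cc2)c2ncccc2c1` gives 26000 nM
- compound 3 `COc1cc(NC(C)CCCNC(=O)Nc2ccc(C(F)(F)F)cc2)c2ncccc2c1` gives 24000 nM

The entry for compound 1 is a limit of the assay and not a number. Among the compounds with values here, compound 3 stands level with compound 2, the only other compound with a number, since the step of a 1.1-fold lower number from compound 2 to compound 3 (0.03 log units; within the scatter) leaves the two indistinguishable.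

Compound 4 `COc1cc(NC(C)CCCNC(=O)Nc2ccc(O)cc2)c2ncccc2c1` carries hydroxy in place of trifluoromethyl on an aromatic carbon, para to a large group (hydroxy in place of trifluoromethyl on an aromatic carbon). The steps of an at least 3.8-fold lower number from compound 1 to compound 2 (0.58 log units; beyond the scatter) and an at least 4.1-fold lower number from compound 1 to compound 3 (0.61 log units; beyond the scatter) are sizeable, but they concern a different change and say little here. Only the swap at this same place bears directly on it, and compound 3 differed from compound 2 there by just a 1.1-fold lower number from compound 2 to compound 3 (0.03 log units; within the scatter). Within the data shown here, no hydroxy compound has been measured, so the range stays wide. The estimated step is a 1.3-fold higher number from compound 3 to compound 4 (0.10 log units; within the scatter), which means none beyond the scatter is expected in this assay. For compound 4 the expected value is 30000 nM, with an estimated range from 12000 nM to 80000 nM.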

Compound 4, half-maximal inhibitory concentration: 34000 nM
Beside the measured number, compound 4's estimate is 1.1-fold (0.05 log units) below it; measured number inside the range.
By their numbers in this assay, from the lowest: compounds 3, 2 and 4 (each within the scatter of the next). At a limit, above all of these: compound 1.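

In this assay, hydroxy at this place cannot be told apart from trifluoromethyl or fluoro: a 1.4-fold higher number from compound 3 to compound 4 (0.15 log units; within the scatter) and a 1.3-fold higher number from compound 2 to compound 4 (0.12 log units; within the scatter). The result extends the earlier fluoro and trifluoromethyl comparison to a group with a hydrogen-bond donor and acceptor, where trifluoromethyl has neither, and the numbers for compounds 2, 3 and 4 still lie within the scatter of one another. The 4-hydroxyphenyl group in place of ((4-fluorophenyl)carbamoyl)amino gives an at least 2.9-fold lower number from compound 1 to compound 4 (0.46 log units; beyond the scatter), a step beyond the scatter that is only a bound, since compound 1 stands at a limit of the assay: the limit of > 100000 nM in this assay, at which 1 of the 4 values shown sits.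

The compounds shown leave open whether an amine or a carboxylic acid on this aromatic carbon would give a number beyond the scatter of these three. They also leave open how far the number for compound 1 lies from the others.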